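This account rests on a few compounds, and the source may have more. Where it says the series, first, only, none or still open, it means among the compounds named here.

Measured in a functional assay on Ramos cells (Homo sapiens) for antiproliferative activity, read by CCK-8 assay, with a stated time of 48 h; on this read-out higher numbers stand for weaker inhibition and lower numbers for stronger inhibition:
- Compound 1 `C=CC(=O)Nc1cccc(-n2cnc3cnc(Nc4ccc(OC)cc4)nc32)c1`: > 40000 nM, a limit
- Compound 2 `C=CC(=O)Nc1cccc(-n2cnc3cnc(Nc4ccc(N5CCN(S(C)(=O)=O)C(C)C5)cc4)nc32)c1`: > 40000 nM, a limit
- Compound 3 `C=CC(=O)Nc1cccc(-n2cnc3cnc(Nc4ccc(N5CCN(CC)CC5)cc4OC)nc32)c1`: > 40000 nM, a limit

None of these three entries is a true number. The whole set offers only (the limit of > 40000 nM in this assay, at which 3 of the 3 values shown sit). Compound 3 therefore has no exact position on the scale, and in this assay compound 3 is recorded only as > 40000 nM, which is a limit.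

Compound 4 `C=CC(=O)Nc1cccc(-n2cnc3cnc(Nc4ccc(N5CCN(S(C)(=O)=O)CC5)cc4OC)nc32)c1` is the next compound to be considered. It keeps the rest of compound 3 and carries methylsulfonyl in place of ethyl on an amine nitrogen in a ring, turning 4-ethylpiperazin-1-yl into 4-(methylsulfonyl)piperazin-1-yl: methylsulfonyl in place of ethyl on an amine nitrogen in a ring.

Among the measured compounds shown here, only one measured step comes close to this change, and it has no usable size: a step that the two limits leave unreadable from compound 1 to compound 2. It brings in 3-methyl-4-(methylsulfonyl)piperazin-1-yl in place of methoxy on an aromatic carbon. Compound 2 also bears a methylsulfonyl group, and its result of > 40000 nM is again a limit.

With no readable step to build on, no change beyond the usual scatter is expected in this assay, and the estimated step is a number no higher from compound 3 to compound 4 (the limit leaves the size open). Another limit is the most likely report. For compound 4 the expected value is 40000 nM, within an estimated range of 15000 nM to 60000 nM.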

Compound 4, half-maximal inhibitory concentration: 38600 nM
Compound 4: middle estimate off by 1.0-fold (0.02 log units), on the high side, within the range that was stated.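

Placing methylsulfonyl in place of ethyl on the amine nitrogen of the six-membered ring gives the first true number in this set: in this assay, compound 4 reads 38600 nM. The change amounts to an at least 1.0-fold lower number from compound 3 to compound 4 (0.01 log units; that floor lies within the scatter), so this ring nitrogen can carry methylsulfonyl and still yield a measurable value, but the printed floor of the step supports no claim of a real gain over ethyl. Compound 4 also has no exact neighbour on the scale to be set against, as the other compounds all stop at the same ceiling: the limit of > 40000 nM in this assay, at which 3 of the 4 values shown sit.

Going by these compounds, the step from compound 1 to compound 2 cannot be read, as both of its ends are limits, so the effect of methylsulfonyl in that other setting stays unknown. On these data alone, whether an acetyl group, a free amine or a longer chain such as propyl on the same ring nitrogen would bring a clearly lower number in this assay remains open.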